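Adding a Methyl Group to a Weaker Core

The source may hold more compounds than are shown below. What is called first, only, known or untested is meant among the compounds shown, and "the series" means these compounds.

Compound 1 `N#Cc1ccc(OCc2ccsc2)cc1/C=C(/C(=O)O)c1ccccc1` and compound 2 `Cc1ccccc1/C(=C\c1cc(OCc2ccsc2)ccc1C#N)C(=O)O` share one core and differ in a single place: methyl in place of hydrogen on an aromatic carbon. In an assay on A10 cells for binding affinity to Endothelin-1 receptor (Rattus norvegicus) (a lower number here means a stronger inhibitor, a higher number a weaker inhibitor), compound 1 gives 80 nM, while compound 2 gives 300 nM, so this change produced a 3.8-fold higher number from compound 1 to compound 2 (0.57 log units; beyond the scatter). Compound 3 `OC/C(=C/c1cc(OCc2ccsc2)ccc1Br)c1ccccc1` is built on a different core; how the two cores differ is not broken down here. In this assay compound 3 gives 2100 nM, the highest of the three numbers. Compound 4 `Cc1ccccc1/C(=C\c1cc(OCc2ccsc2)ccc1Br)CO` has not yet been measured and differs from compound 3 by methyl in place of hydrogen on an aromatic carbon, the same change that separates compound 1 from compound 2. The step expected for compound 4 is a 3.3-fold higher number from compound 3 to compound 4 (0.52 log units; beyond the scatter), resting on the measured 3.8-fold higher number from compound 1 to compound 2 (0.57 log units; beyond the scatter). On that basis compound 4 is estimated at 7000 nM, with a range from 3000 nM to 20000 nM.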

Compound 4, half-maximal inhibitory concentration: 600 nM
Compound 4: middle estimate off by 12-fold (1.07 log units), on the high side; measured number outside the range, below it.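

Going from phenyl to 2-methylphenyl gives a 3.5-fold lower number from compound 3 to compound 4 (0.54 log units; beyond the scatter) in this assay. The same change therefore moves the number in opposite directions on the two cores, and the step measured on one core does not carry over to the other: the same change on two cores in this assay, a 3.8-fold higher number (0.57 log units; beyond the scatter) from compound 1 to compound 2 and a 3.5-fold lower number (0.54 log units; beyond the scatter) from compound 3 to compound 4, 13-fold (1.12 log units) apart, beyond the scatter of two such steps. Among the compounds shown here, this rests on only two pairs of compounds, and it does not show which of the differences between the cores lies behind the reversal, or how the change would behave on any third core.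

The compounds shown leave open what an ethyl or methoxy group would do in place of the methyl on either core. They also leave open how the methyl would behave on a core that pairs the carboxylic acid with bromine.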